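The source may report more compounds than this note shows. Statements on the series, on what has been measured and on what is new or still open speak of the compounds shown alone.

Measured compounds:

Compound 1 `Cc1ccc(C(C)C)c(OCc2nnc(SCC(=O)Nc3ccc([N+](=O)[O-])cc3)n2Cc2ccccc2)c1` gives 11.2 ug/mL in a toxicity assay on MT4 cells (Homo sapiens) for cytotoxicity, read by MTT assay, with a stated time of 5 days; on this read-out higher numbers stand for lower toxicity in this test and lower numbers for higher toxicity in this test.
Compound 2 `CCOC(=O)c1ccc(NC(=O)CSc2nnc(COc3cc(C)ccc3C(C)C)n2Cc2ccccc2)cc1` gives 19.8 ug/mL in this assay.
Compound 3 `O=C(CSc1nnc(COc2ccc3ccccc3c2)n1Cc1ccccc1)Nc1ccc([N+](=O)[O-])cc1` gives only a limit of the assay in this assay, >= 116 ug/mL.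

Compound 1 and compound 2 share a core and differ by ethoxycarbonyl in place of nitro on an aromatic carbon, a change that produced a 1.8-fold higher number from compound 1 to compound 2 (0.25 log units; within the scatter). Compound 3 differs from compound 1 in the core, by naphthalen-2-yl in place of 2-isopropyl-5-methylphenyl on an oxygen on a saturated carbon, and that step was an at least 10-fold higher number from compound 1 to compound 3 (1.01 log units; beyond the scatter); compound 3 sits at the limit of >= 116 ug/mL in this assay, at which 1 of the 3 values shown sits, so its true value is not known as a number.

Compound 4 `CCOC(=O)c1ccc(NC(=O)CSc2nnc(COc3ccc4ccccc4c3)n2Cc2ccccc2)cc1` has not yet been measured. It differs from compound 3 by ethoxycarbonyl in place of nitro on an aromatic carbon, which is the same change as the one made from compound 1 to compound 2, at the same place; the change occurs twice among the compounds shown. The cores of compound 3 and compound 4, against those of compound 1 and compound 2, differ by the change described above as naphthalen-2-yl in place of 2-isopropyl-5-methylphenyl on an oxygen on a saturated carbon.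

The expected step is a step that the limit leaves unreadable from compound 3 to compound 4, a step on the same order as a 1.8-fold higher number from compound 1 to compound 2 (0.25 log units; within the scatter), which lay within the scatter. That expectation rests on compound 3 already giving only a limit, >= 116 ug/mL, so that a small change would most likely leave compound 4 at the limit as well. Compound 4 is therefore estimated at about 160 ug/mL, most likely between 80 ug/mL and 320 ug/mL, with a good chance that the assay again reports only a limit.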

Compound 4, half-maximal cytotoxic concentration: >= 90.7 ug/mL
Compound 4: a limit, no number; the forecaster's own chance of this, stated with the estimate: 75%; the middle value lies beyond the limit too.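

In this assay, naphthalen-2-yl in place of 2-isopropyl-5-methylphenyl gave an at least 4.5-fold higher number from compound 2 to compound 4 (0.66 log units; beyond the scatter), so this change moved the number the same way in the nitro pair and in the ethoxycarbonyl pair: the same change on two cores in this assay, an at least 10-fold higher number (1.01 log units; beyond the scatter) from compound 1 to compound 3 and an at least 4.5-fold higher number (0.66 log units; beyond the scatter) from compound 2 to compound 4; the limit leaves it open whether they differ
Compound 4 gives >= 90.7 ug/mL, which is a limit of the assay and not a number.
The step from ethoxycarbonyl in place of nitro on the naphthalen-2-yl core cannot be read, so the series does not show whether that change carries over from the core of compound 1, and it shows the direction of the naphthalen-2-yl change on two compounds without showing that its size is the same.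

Going by these compounds, the true values of compound 3 and compound 4 remain open, and with them how far the naphthalen-2-yl change really moves the number in either pair. Also open, on these data alone, is what an amine or a carboxylic acid in place of nitro on the aromatic carbon would give on either core, and whether a longer chain than ethoxycarbonyl at that place would leave the number of compound 2 within the scatter.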